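Changing the acid-bearing chain on the shared core

This account rests on a few compounds, and the source may have more. Where it says the series, first, only, none or still open, it means among the compounds named here.

Compound 1 `Cc1ccc(S(=O)(=O)N[C@H]2CCC=C2CCCCOCC(=O)O)cc1` carries a 4-methylphenyl group on its sulfonyl sulfur and a 3-(carboxymethoxy)propyl chain on the ring. In a functional assay on a cell-free system (plasma) for inhibition of thromboxane A2 receptor (Homo sapiens), read by turbidimetry (on this read-out lower numbers stand for stronger inhibition and higher numbers for weaker inhibition), compound 1 gives 1900 nM, level with compound 2 `O=C(O)COCCCCC1=CCC[C@@H]1NS(=O)(=O)c1ccccc1[N+](=O)[O-]` at 1900 nM, and these two stand highest of the three numbers, while compound 3 `O=C(O)COCCCCC1=CCC[C@@H]1NS(=O)(=O)c1ccc(F)cc1F` gives 1800 nM. Swapping the aryl group on the sulfonyl sulfur changed little: no change at the digits printed from compound 1 to compound 2 (within the scatter), a 1.1-fold lower number from compound 1 to compound 3 (0.02 log units; within the scatter) and a 1.1-fold lower number from compound 2 to compound 3 (0.02 log units; within the scatter) all lie within the scatter.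

Compound 4 `Cc1ccc(S(=O)(=O)N[C@H]2CCC=C2C/C=C\CCC(=O)O)cc1` differs from compound 1 elsewhere: 4-carboxybut-1-en-1-yl in place of 3-(carboxymethoxy)propyl on a saturated chain carbon bound to a double-bonded ring carbon. Within the data shown here, none of the measured steps touches this chain; they all concern the aryl group and were flat. There is therefore no measured basis for a direction, and a step of any size cannot be ruled out. The expectation for compound 4 is set at 1500 nM, between 300 nM and 8000 nM, which means an expected step of a 1.3-fold lower number from compound 1 to compound 4 (0.10 log units; within the scatter).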

Compound 4, half-maximal inhibitory concentration: 1800 nM
Compound 4: middle estimate off by 1.2-fold (0.08 log units), on the low side, and the stated range covers the measured number.
By their numbers in this assay, from the lowest: compounds 3, 4, 1 and 2 (each within the scatter of the next).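

Among these compounds, this is the first measured change to the acid-bearing chain rather than the aryl group, and in this assay the data show a 1.1-fold lower number from compound 1 to compound 4 (0.02 log units; within the scatter) when 4-carboxybut-1-en-1-yl replaces 3-(carboxymethoxy)propyl. At this place, on a saturated chain carbon bound to a double-bonded ring carbon, going from 8 heavy atoms to 7 and from 1 double bond to 2 therefore gives no readable change in the number, so this chain swap is as flat as the aryl swaps. No supporting measurement is available to explain why the two chains read alike.

Still open, from the compounds shown here alone, is how a longer chain, or an amide in place of the carboxylic acid, would read. Also open is whether aryl swaps stay as flat on the 4-carboxybut-1-en-1-yl chain, which is shown only with the 4-methylphenyl group.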